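The compounds below may be only part of what the source reports. "The series", "measured", "known", "first", "only" and "open" are said of these compounds alone.

Compound 1 `Cc1ccc(C(=O)NNC(=S)Nc2csc(-c3ccccc3)c2)cc1` and compound 2 `Cc1ccc(C(=O)NNC(=S)Nc2csc(-c3ccc(C)cc3)c2)cc1` share a core and differ in one place: the change (methyl in place of hydrogen on an aromatic carbon). In a functional assay on Hs 683 cells (Homo sapiens) for inhibition, read by colorimetric assay and MTT assay, with a stated time of 72 h (a lower number here means a stronger inhibitor, a higher number a weaker inhibitor), compound 1 gives 37000 nM. In the same test compound 2 gives 40000 nM. The step between them, a 1.1-fold higher number from compound 1 to compound 2 (0.03 log units; within the scatter), lies within the usual scatter of repeated measurements, so the two numbers cannot be told apart.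

Compound 3 `COc1ccc(C(=O)NNC(=S)Nc2csc(-c3ccccc3)c2)cc1OC` differs from compound 1 in more than one place; the difference between the two cores is not broken down here. In this assay compound 3 gives 22000 nM. Its number sits within the scatter of both compound 1 and compound 2, so no order among the three can be claimed.

Compound 4 `COc1ccc(C(=O)NNC(=S)Nc2csc(-c3ccc(C)cc3)c2)cc1OC` has not yet been measured. It stands to compound 3 as compound 2 stands to compound 1: the change (methyl in place of hydrogen on an aromatic carbon), made at the same kind of place, described in the same words for both pairs, so it is the same change. Among the compounds with values here, the only observation of this change, a 1.1-fold higher number from compound 1 to compound 2 (0.03 log units; within the scatter), gave a number within the scatter. On that one observation, a step of similar size is expected from compound 3, estimated as a 1.1-fold higher number from compound 3 to compound 4 (0.04 log units; within the scatter) in this assay. The value of compound 4 in this assay is therefore expected to be about 24000 nM, most likely between 12000 nM and 48000 nM, given that it rests on a single prior step and on compound 3 at 22000 nM.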

Compound 4, half-maximal inhibitory concentration: 39000 nM
Compound 4: the middle estimate sits 1.6-fold (0.21 log units) below what was measured; the range from low to high includes it.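

In this assay, the change from phenyl to 4-methylphenyl, placed on an aromatic carbon para to a large group, gives a 1.8-fold higher number from compound 3 to compound 4 (0.25 log units; within the scatter), so on this second core too the step cannot be told from the usual scatter of repeated measurements. Set beside the earlier step on the other core, the new step does not differ from it: the same change on two cores in this assay, a 1.1-fold higher number (0.03 log units; within the scatter) from compound 1 to compound 2 and a 1.8-fold higher number (0.25 log units; within the scatter) from compound 3 to compound 4, 1.6-fold (0.21 log units) apart, within the scatter of two such steps. This shows that, across these two pairs, the methyl group carried from one core to the other without any step or any gap between steps that rises above the scatter, but it does not show that the change has no effect, that the two steps are truly equal, or that the same would hold on any further core or in any other test.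

The compounds shown have only hydrogen or methyl at this place, so they leave open whether a different group there, such as a chlorine, a methoxy group, an amine or a carboxylic acid, would give a step beyond the scatter. They also leave open whether any such step would carry between the two cores in the way the methyl step does here.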